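Compound 4: 1H-pyrazol-1-yl replacing 1H-pyrrol-2-yl

This account rests on a few compounds, and the source may have more. Where it says the series, first, only, none or still open, it means among the compounds named here.

Within the data shown here, in a functional assay on A549 cells (Homo sapiens) for cytotoxicity, read by MTT assay, with a stated time of 72 h (on this read-out lower numbers stand for stronger inhibition and higher numbers for weaker inhibition), compound 1 `COc1ccc2[nH]c(-c3ccc[nH]3)c(C3CC(=O)NC3=O)c2c1` gives 4000 nM, while compound 3 `COc1ccc2[nH]c(-c3ccc[nH]3)cc2c1` gives 55000 nM, the highest exact number so far. That gap is a 14-fold higher number from compound 1 to compound 3 (1.14 log units; beyond the scatter), but it concerns hydrogen in place of 2,5-dioxopyrrolidin-3-yl and sets no size for the next change. Compound 4 `COc1ccc2[nH]c(-n3cccn3)cc2c1` has 1H-pyrazol-1-yl in place of 1H-pyrrol-2-yl on an aromatic carbon, next to the ring nitrogen: 1H-pyrazol-1-yl in place of 1H-pyrrol-2-yl on an aromatic carbon. Compound 2 `c1ccc2[nH]c(-n3cccn3)cc2c1`, also carrying 1H-pyrazol-1-yl, reads > 100000 nM, a limit of the assay and not a number, and this points compound 4 towards weaker inhibition. A small rise is therefore expected, as a 1.5-fold higher number from compound 3 to compound 4 (0.16 log units; within the scatter). For compound 4 the estimated value is 80000 nM, with an expected range of 35000 nM to 150000 nM.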

Compound 4, half-maximal inhibitory concentration: > 100000 nM
Compound 4 ended at the assay's limit; the forecaster's own chance of this, stated with the estimate: 45%; middle value at least 1.2-fold (0.09 log units) from the limit.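

In this assay the step to 1H-pyrazol-1-yl on this aromatic carbon, with the rest of compound 3 kept, reads only as a floor (an at least 1.8-fold higher number from compound 3 to compound 4 (0.25 log units; that floor lies within the scatter)). Going by these compounds, its true size therefore stays unknown, and the change shows no gain in inhibition. The step between compound 2 and compound 4 cannot be read, and both 1H-pyrazol-1-yl compounds end at a limit and not at a number: the limit of > 100000 nM in this assay, at which 2 of the 4 values shown sit.

Open, on these data alone, is whether 2,5-dioxopyrrolidin-3-yl on the shared core would bring a 1H-pyrazol-1-yl compound to a measurable value. Also open, as far as these compounds go, is how an aminomethyl group or a carboxylic acid would read in place of the ring at this position.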